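The source may report more compounds than this note shows. Statements on the series, on what has been measured and on what is new or still open speak of the compounds shown alone.

Measured so far in an ADME assay on NIH3T3 cells (Mus musculus) for cytotoxicity, read by MTT assay, with a stated time of 24 h; a lower number here means a stronger inhibitor, a higher number a weaker inhibitor:

compound 1 `Cn1nnnc1SCC(=O)N/N=c1/scc(-c2ccc(C#N)cc2)n1-c1ccccc1` gives 213 ug/mL

compound 2 `Cn1nnnc1SCC(=O)N/N=c1/scc(-c2ccc([N+](=O)[O-])cc2)n1-c1ccccc1` gives 167 ug/mL

compound 3 `O=C(CSc1nnnn1-c1ccccc1)N/N=c1/scc(-c2ccccc2)n1-c1ccccc1` gives 417 ug/mL

Compound 3 stands at the highest of the three numbers in this assay; its gap to compound 1 is within the scatter, while its gap to compound 2 lies beyond it. The only single-change step measured among these compounds, a 1.3-fold lower number from compound 1 to compound 2 (0.11 log units; within the scatter), swaps one group on the distal aromatic carbon and is itself within the scatter.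

Compound 4 `Cn1nnnc1SCC(=O)N/N=c1/scc(-c2ccccc2)n1-c1ccccc1` has not yet been measured. Its change from compound 3 is methyl in place of phenyl on an aromatic nitrogen. Among the compounds with values here, compounds 1 and 2 already carry the 1-methyl-1H-tetrazol-5-yl group, but each also differs from compound 3 at the distal aromatic carbon, so no measured step isolates this change. The nearest guide is that compound 1, with the methyl tetrazole, gives 213 ug/mL, and compound 3 gives 417 ug/mL, a difference within the scatter.

Within the data shown here, with no direct precedent, no step beyond the scatter is expected; the estimate for compound 4 is 280 ug/mL (range 130 ug/mL to 600 ug/mL), an expected step of a 1.5-fold lower number from compound 3 to compound 4 (0.17 log units; within the scatter).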

Compound 4, half-maximal inhibitory concentration: 173 ug/mL
For compound 4 the middle estimate is 1.6-fold (0.21 log units) above the measured one; low and high end bracket the measured number.
By their numbers in this assay, from the lowest: compounds 2, 4, 1 and 3 (each within the scatter of the next, the first and the last beyond it).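

In this assay, within the data shown here, the swap from 1-phenyl-1H-tetrazol-5-yl to 1-methyl-1H-tetrazol-5-yl gives a 2.4-fold lower number from compound 3 to compound 4 (0.38 log units; beyond the scatter) and is the first single change here to step beyond the scatter. Changes on the aromatic carbon stay within the scatter, both for hydrogen in place of cyano (a 1.2-fold lower number from compound 1 to compound 4 (0.09 log units; within the scatter)) and for hydrogen in place of nitro (a 1.0-fold higher number from compound 2 to compound 4 (0.02 log units; within the scatter)), so among these compounds only the group on the aromatic nitrogen shifts the number clearly. No measurement at hand explains this shift.

The compounds shown leave open what groups other than methyl and phenyl, such as ethyl or benzyl, would do on this nitrogen. As far as these compounds go, whether the same swap gives a similar step with cyano, nitro or an amine on the aromatic carbon also remains open.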